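A few compounds are considered here, and "the series" means these few. Any claim that something is new, unique, unknown or untested is made for them only; others in the source may bear on it.

Three close relatives of one core have been tested, and a fourth is about to be. Compound 1 `CC[C@H](C)[C@H](NC(=O)c1cccc(Cn2ccnc2)c1)C(=O)Nc1nccs1` carries a 1,3-thiazol-2-yl group on its amide-type nitrogen. In an assay on HEK293 cells for displacement of a labelled ligand from Type-2 angiotensin II receptor (Homo sapiens), tested at 10 uM (on this read-out lower numbers stand for a weaker effect and higher numbers for a stronger effect at the one concentration tested), compound 1 gives 17%, and it is the only one of the three with a reported number. Compound 2 `CC[C@H](C)[C@H](NC(=O)c1cccc(Cn2ccnc2)c1)c1nn[nH]n1` is reported in this assay as "not active" (no number reported), and compound 3 `CC[C@H](C)[C@H](NC(=O)c1cccc(Cn2ccnc2)c1)C(N)=O` likewise as "not active" (no number reported); for both, no figure was given. So compound 1 stands alone as the one entry with a measurable read-out, while the two others fall at or near the floor of what this read-out can resolve.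

Compound 4 `CC[C@H](C)[C@H](NC(=O)c1cccc(Cn2ccnc2)c1)C(=O)NC#N` replaces the five-membered ring of compound 1 with a far smaller group: cyano in place of 1,3-thiazol-2-yl on an amide-type nitrogen. No pair of measured compounds traces this exact change, so the expectation rests on the spread shown by compound 1 against compound 3. Since the modest figure of compound 1 is already close to the level where the others drop out of view, the step from compound 1 to compound 4 is expected to be small and downward, a number 7 percentage points lower from compound 1 to compound 4 (within the scatter), and it may well lie within the ordinary scatter. Compound 4 is therefore expected to give about 10%, most likely between 0% and 25%.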

Compound 4, a percentage reported as inhibition, at one concentration (the size of the read-out at that concentration, not a potency): 9%
For compound 4 the middle estimate is 1 percentage points above the measured one, and the stated range covers the measured number.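

Exchanging 1,3-thiazol-2-yl for cyano on the amide-type nitrogen gives, in this assay, a number 8 percentage points lower from compound 1 to compound 4 (within the scatter), so the whole five-membered aromatic ring can go from this position without a difference that stands out from the scatter of repeated measurements. Compound 4 still gives a figure (9%) while compound 3, which carries neither group on that nitrogen, is reported as "not active" (no number reported) in the same read-out, so a ring on this nitrogen is not needed for a number to be reported, although the figures for compound 1 and compound 4 are both modest. Nothing shown here offers a reason for this outcome.

What the compounds shown leave open is how other groups on this nitrogen would read, for example a methyl group, a phenyl ring or a longer alkyl chain, and whether any of them would lift the figure clear of the scatter. As far as these compounds go, each figure also comes from a single concentration, so none is a potency, and how these compounds would compare across a range of concentrations remains unknown.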